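Working notes: a two-compound series and an unmeasured analogue

The source may report more compounds than this note shows. Statements on the series, on what has been measured and on what is new or still open speak of the compounds shown alone.

compound 1 `O=c1oc2ccccc2cc1C1=NN(c2ccccc2)[C@@H](c2ccccc2)C1`: 32.7%
compound 2 `COc1ccc([C@H]2CC(c3cc4ccccc4oc3=O)=NN2c2ccccc2)cc1`: 36.2%

Both measured compounds were read in a functional assay on the whole organism (strain albino) for inhibition, with Rattus norvegicus as the target, read by paw edema, with stated times of 1 h and 4 h, at a dose of 200 mg/kg by the oral route; a lower number here means less inhibition, a higher number more inhibition at the dose given (going by the name of the read-out). Compound 1 gives 32.7% and compound 2 gives 36.2%. Compound 2 has the highest of the two numbers, but its nearest neighbour is compound 1 and the step of a number 3.5 percentage points higher from compound 1 to compound 2 (within the scatter) lies within the scatter, so no order between the two can be stated.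

Compound 3 `O=c1oc2ccccc2cc1C1=NN(c2ccccc2)[C@@H](/C=C/c2ccccc2)C1` is not yet measured. It differs from compound 2 as follows: 2-phenylethenyl in place of 4-methoxyphenyl on a saturated ring carbon.

Within the data shown here, the only measured step, a number 3.5 percentage points higher from compound 1 to compound 2 (within the scatter), concerns methoxy in place of hydrogen on an aromatic carbon and not the exchange of a whole group on the saturated ring carbon, so it bears on the new change only loosely. Among the measured compounds shown here, it shows that the one change made so far left the number within the scatter. For the measured compounds named here, no step exists for 2-phenylethenyl in place of 4-methoxyphenyl. For compound 3 the expected step is therefore a number 4.2 percentage points lower from compound 2 to compound 3 (within the scatter), none beyond the scatter, with a wide range because the measured evidence is only a number 3.5 percentage points higher from compound 1 to compound 2 (within the scatter). Compound 3 is estimated at 32%, with a range from 22% to 42%.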

Compound 3, a percentage reported as inhibition, in the whole organism at one dose (the size of the read-out at that dose, not a potency): 42.5%
Estimate against measurement, compound 3: 10.5 percentage points below; measured number above the stated range.
By their numbers in this assay, from the lowest: compounds 1, 2 and 3 (each within the scatter of the next).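

Notes on the saturated ring carbon next to the ring nitrogen: in this assay this is the first reading of a whole-group exchange at this place, with a number 6.3 percentage points higher from compound 2 to compound 3 (within the scatter) for 2-phenylethenyl in place of 4-methoxyphenyl and a number 9.8 percentage points higher from compound 1 to compound 3 (within the scatter) for 2-phenylethenyl in place of phenyl. Both steps lie within the scatter, so this position accepts a group carrying a double bond outside aromatic rings, and no hydrogen-bond acceptor, with no change that can be told apart from the scatter, and phenyl, 4-methoxyphenyl and 2-phenylethenyl cannot be ranked here. Nothing at hand accounts for the size of either step.

Going by these compounds, all three groups at this carbon carry a six-membered aromatic ring of carbon only, so it remains open whether a group without one, such as a plain butyl chain, a dimethylamino-bearing chain or a carboxylic acid, would move the number beyond the scatter. Also open, on these data alone, is how the series responds to exchange of the phenyl group on the neighbouring ring atom, for example for a pyridine ring.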